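A Second Carbamoyl Group on Compound 2

This account rests on a few compounds, and the source may have more. Where it says the series, first, only, none or still open, it means among the compounds named here.

Measured in a functional assay on A-431 cells (Homo sapiens) for antiproliferative activity; on this read-out lower numbers stand for stronger inhibition and higher numbers for weaker inhibition:
- compound 1 `CO[C@@H]1[C@H](OC(=O)NC(=O)CCl)CO[C@]2(COC(C)(C)O2)[C@@]1(OC)C1(C)CO1`: 39000 nM
- compound 2 `CO[C@@H]1[C@H](OC(=O)NC(=O)CCl)CO[C@]2(COC(=O)O2)[C@@]1(O)CCCCCc1ccccc1`: 11000 nM
- compound 3 `CO[C@@H]1[C@H](OC(=O)NC(=O)CCl)CO[C@]2(COC(C)(C)O2)[C@]1(CCCCCc1ccccc1)OC(=O)NC(=O)CCl`: 1200 nM

Of these three numbers, compound 2 holds the middle place. Its value lies below that of compound 1 and above that of compound 3, and both gaps are beyond the scatter.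

The unmeasured compound 4 `CO[C@@H]1[C@H](OC(=O)NC(=O)CCl)CO[C@]2(COC(=O)O2)[C@]1(CCCCCc1ccccc1)OC(=O)NC(=O)CCl` departs from compound 2 in one place: ((chloromethyl)carbonyl)carbamoyl in place of hydrogen on an oxygen on a saturated carbon. A ((chloromethyl)carbonyl)carbamoyl group stands in place of hydrogen on an oxygen on a saturated carbon, so that hydroxy becomes (((chloromethyl)carbonyl)carbamoyl)oxy.

For the measured compounds named here, no measured pair of compounds differs by a single change, so the size of this step cannot be read directly. The closest guide is compound 3, which gives 1200 nM and also carries this group in place of that hydrogen. It differs from compound 2 elsewhere as well, so the guide is a loose one. In this assay, a step toward a lower number, beyond the scatter, is expected. The expected step is a 6.1-fold lower number from compound 2 to compound 4 (0.79 log units; beyond the scatter). Compound 4 is estimated at 1800 nM, with an expected range of 500 nM to 6500 nM.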

Compound 4, half-maximal inhibitory concentration: 2000 nM
The estimate for compound 4 lay 1.1-fold (0.05 log units) below the measured number; low and high end bracket the measured number.
By their numbers in this assay, from the lowest: compounds 3 and 4 (each within the scatter of the next); then compound 2; then compound 1.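

In this assay, exchanging hydroxy for (((chloromethyl)carbonyl)carbamoyl)oxy on this oxygen on a saturated carbon now has a direct reading, with nothing else in the structure altered: the step is a 5.5-fold lower number from compound 2 to compound 4 (0.74 log units; beyond the scatter), modest in size but beyond the scatter. Compound 3 already carried the same group, but it differed from compound 2 elsewhere as well, so it could not separate this change from the others, whereas compound 4 shows that this single change is enough to produce a lower number, and compound 3 and compound 4 stand within the scatter of each other. No measurement bears on why the number moves with this change, so the result stays an observation about this one position in this one cell assay.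

The compounds shown leave open whether the whole entering group is needed at this oxygen, or whether a plain carbamoyl or an acetyl group in place of the same hydrogen would give a similar step. They also leave open what happens to the number if the chlorine of the entering group is replaced by hydrogen, or if the phenyl-bearing pentyl chain is exchanged for a shorter chain while this group stays in place.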